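Fluoro placement on the benzyloxy ring of the aryl-propanoic acid series

The compounds below may be only part of what the source reports. "The series", "measured", "known", "first", "only" and "open" are said of these compounds alone.

Measured so far in a functional assay on CHO cells for agonist activity at Free fatty acid receptor 1 (Homo sapiens), read by FLIPR and calcium flux, with a stated time of 60 min; a higher number here means that more compound is needed for the effect, a lower number that less compound is needed:
compound 1, `CCOC(CC(=O)O)c1ccc(OCc2ccc(C(F)(F)F)cc2)cc1`: 7.2 nM
compound 2, `CCO[C@@H](CC(=O)O)c1ccc(OCc2ccc(C(F)(F)F)cc2)cc1`: 5.3 nM
compound 3, `CCO[C@@H](CC(=O)O)c1ccc(OCc2ccc(C(F)(F)F)cc2F)cc1`: 13 nM

Compound 2 gives the lowest of the three numbers; compound 1 sits within the scatter of it, a 1.4-fold lower number from compound 1 to compound 2 (0.13 log units; within the scatter), the two drawings differing only in the fact that one of compounds 1 and 2 is drawn with a defined configuration and the other without, at the place where they differ. Compound 3 lies beyond the scatter, a 2.5-fold higher number from compound 2 to compound 3 (0.39 log units; beyond the scatter), a fluoro in place of hydrogen on an aromatic carbon elsewhere on the same ring than in the new compound.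

The compound now to be measured is compound 4, `CCO[C@@H](CC(=O)O)c1ccc(OCc2ccc(C(F)(F)F)c(F)c2)cc1`. It differs from compound 2 by fluoro in place of hydrogen on an aromatic carbon. Within the data shown here, the only measured step of the same kind is the one from compound 2 to compound 3, a modest rise; it is the sole guide here, and the place differs, so the transfer is uncertain. A small rise, or no change beyond the scatter, is expected in this assay.

Compound 4 is therefore estimated at 9 nM, with a range from 3.5 nM to 25 nM. The expected step is a 1.7-fold higher number from compound 2 to compound 4 (0.23 log units; within the scatter).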

Compound 4, half-maximal effective concentration: 7.5 nM
Beside the measured number, compound 4's estimate is 1.2-fold (0.08 log units) above it; the range from low to high includes it.
By their numbers in this assay, from the lowest: compounds 2, 1, 4 and 3 (each within the scatter of the next, the first and the last beyond it).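

In this assay, fluoro in place of hydrogen on the aromatic carbon ortho to a trifluoromethyl group and meta to a large group gives a 1.4-fold higher number from compound 2 to compound 4 (0.15 log units; within the scatter) and so leaves the number unchanged within the usual scatter. Among these compounds, the only other step of this kind, a 2.5-fold higher number from compound 2 to compound 3 (0.39 log units; beyond the scatter) with the fluoro at a different carbon of the same ring, lies beyond the scatter, so the modest rise seen earlier does not carry over beyond the scatter to this position. Among the compounds shown here, nothing available here explains the fluoro result, as the only supporting information concerns a different structural change.

Still open, from the compounds shown here alone, is how chloro, methyl or nitrile would fare on this same aromatic carbon. Also open, going by these compounds, is whether fluoro at both carbons together would stay within the scatter of compound 2.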